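Acetyl for Trifluoromethyl on Two Related Cores

The source may hold more compounds than are shown below. What is called first, only, known or untested is meant among the compounds shown, and "the series" means these compounds.

Compound 1 `CC1(C)Oc2ccc(C(F)(F)F)cc2[C@@H](/N=C(\NC#N)Nc2ccccc2)[C@@H]1O` gives 9200 nM in a functional assay (aorta) for inhibition, with Rattus norvegicus as the target; on this read-out lower numbers stand for stronger inhibition and higher numbers for weaker inhibition. Compound 3 `CC(=O)c1ccc2c(c1)[C@@H](/N=C(\NC#N)Nc1ccccc1)[C@H](O)C(C)(C)O2` carries acetyl in place of trifluoromethyl on an aromatic carbon and gives 4000 nM, so the step is a 2.3-fold lower number from compound 1 to compound 3 (0.36 log units; beyond the scatter). Compound 2 `CC1(C)Oc2ccc(C(F)(F)F)cc2[C@@H](NC(=O)Nc2ccccc2)[C@@H]1O` gives 1100 nM, the lowest number of the three; the difference between its core and the core of compound 1 is not broken down here. Compound 4 `CC(=O)c1ccc2c(c1)[C@@H](NC(=O)Nc1ccccc1)[C@H](O)C(C)(C)O2` has not been measured yet; it differs from compound 2 by acetyl in place of trifluoromethyl on an aromatic carbon, the same change as from compound 1 to compound 3 at the same place. Within the data shown here, the step from compound 2 to compound 4 is expected to be about a 2.2-fold lower number from compound 2 to compound 4 (0.34 log units; beyond the scatter), beside the earlier one, because only the single step of a 2.3-fold lower number from compound 1 to compound 3 (0.36 log units; beyond the scatter) shows this change. Compound 4 is therefore estimated at 500 nM, between 200 nM and 1300 nM.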

Compound 4, half-maximal inhibitory concentration: 1200 nM
Compound 4: the middle estimate sits 2.4-fold (0.38 log units) below what was measured; measured number inside the range.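

In this assay, acetyl in place of trifluoromethyl gives a 1.1-fold higher number from compound 2 to compound 4 (0.04 log units; within the scatter), so on this core the change leaves no reading beyond the scatter. Set beside the earlier step, the two results cannot be told apart: the same change on two cores in this assay, a 2.3-fold lower number (0.36 log units; beyond the scatter) from compound 1 to compound 3 and a 1.1-fold higher number (0.04 log units; within the scatter) from compound 2 to compound 4, 2.5-fold (0.40 log units) apart, within the scatter of two such steps. Among these compounds, this shows that the series gives no firm sign of the change acting differently on the two cores, but it does not show that the change carries over with the same size, as only two pairs bear on the question.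

The compounds shown hold only trifluoromethyl and acetyl at this aromatic carbon. From the compounds shown here alone, how an amine, a carboxylic acid or a longer acyl chain there would read on either core remains open.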